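The compounds below may be only part of what the source reports. "The series", "measured", "known", "first", "only" and "open" are said of these compounds alone.

Measured compounds in the series:

- compound 1 `c1c[nH]c(-c2ccccc2OCC2=NCCN2)c1`: 1 nM
- compound 2 `c1ccc(-c2ccns2)c(OCC2=NCCN2)c1`: 12.6 nM

For the measured compounds named here, in a functional assay for activation of Alpha-1B adrenergic receptor (Homo sapiens), read by calcium flux (on this read-out higher numbers stand for an effect only at larger amounts of compound and lower numbers for an effect already at smaller amounts), compound 2 gives the higher of the two numbers so far; its nearest neighbour is compound 1, and the one-place step a 13-fold higher number from compound 1 to compound 2 (1.10 log units; beyond the scatter) separates them. Both carry the same core with the group on an aromatic carbon differing between them.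

Compound 3 `Cc1ccc(-c2ccccc2OCC2=NCCN2)s1` is not yet measured. It differs from compound 2 in one place: 5-methylthiophen-2-yl in place of 1,2-thiazol-5-yl on an aromatic carbon. Going by the values given here, only one measured step bears on this position, the step from compound 1 to compound 2, and it was large. That step went from a five-membered ring with one hetero atom and a hydrogen-bond donor to a ring with two hetero atoms and no donor; the present change goes back to a ring with one hetero atom, but without the donor and with a methyl added. The expectation for compound 3 in this assay is therefore a number somewhere between those of its two neighbours, with an estimated step of a 2.1-fold lower number from compound 2 to compound 3 (0.32 log units; beyond the scatter), a modest move downward that may not clear the scatter. Compound 3 is estimated at 6 nM, with a range from 1.5 nM to 25 nM.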

Compound 3, half-maximal effective concentration: < 100000 nM
Compound 3: only a limit was reported; the forecaster's own chance of this, stated with the estimate: 2%; the middle value lies beyond the limit too.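

In this assay compound 3 gives < 100000 nM, which is a limit and not a number. The steps from compound 1 and from compound 2 to compound 3 cannot be read from it. The compounds shown leave open how the 5-methylthiophen-2-yl group of compound 3 compares with the groups of compound 1 and compound 2 on this aromatic carbon.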